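Series notes: phenyl for 4-fluorobenzyl, HeLa cytotoxicity

This account rests on a few compounds, and the source may have more. Where it says the series, first, only, none or still open, it means among the compounds named here.

Measured in an ADME assay on HeLa cells (Homo sapiens) for cytotoxicity, read by MTT assay; a lower number here means a stronger inhibitor, a higher number a weaker inhibitor:
compound 1 `COc1ccc(C[C@H]2COC(=O)[C@@H]2Cc2ccc(OCc3cn(Cc4ccc(F)cc4)nn3)c(OC)c2)cc1OC` gives 198000 nM
compound 2 `CCN1CCN(C(=O)CCC(=O)Oc2ccc(C[C@H]3C(=O)OC[C@@H]3Cc3ccc(OC)c(OC)c3)cc2OC)CC1` gives 190000 nM
compound 3 `COC(=O)[C@H](CCSC)NC(=O)CCC(=O)Oc1ccc(C[C@H]2C(=O)OC[C@@H]2Cc2ccc(OC)c(OC)c2)cc1OC` gives 199000 nM

Compound 1 stands second highest of the three numbers; its gaps to compound 3 and to compound 2 are both within the scatter, so no order among them can be read. Within the data shown here, the one measured step, a 1.0-fold higher number from compound 2 to compound 3 (0.02 log units; within the scatter), concerns a group on a carbonyl carbon and does not bear on the present change.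

Compound 4 `COc1ccc(C[C@H]2COC(=O)[C@@H]2Cc2ccc(OCc3cn(-c4ccccc4)nn3)c(OC)c2)cc1OC` differs from compound 1 thus: phenyl in place of 4-fluorobenzyl on an aromatic nitrogen. Among the measured compounds shown here, no measured step touches this position, so nothing argues for movement; the expected step is a 1.0-fold higher number from compound 1 to compound 4 (0.00 log units; within the scatter), none beyond the scatter. Compound 4 is estimated at 200000 nM, range 100000 nM to 400000 nM.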

Compound 4, half-maximal inhibitory concentration: 124000 nM
For compound 4 the middle estimate is 1.6-fold (0.21 log units) above the measured one; measured number inside the range.
By their numbers in this assay, from the lowest: compounds 4, 2, 1 and 3 (each within the scatter of the next).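

In this assay, among these compounds, phenyl in place of 4-fluorobenzyl on an aromatic nitrogen gives a 1.6-fold lower number from compound 1 to compound 4 (0.20 log units; within the scatter), the first measured step at this position. Between these two aromatic groups, the position shows no change that can be read beyond the scatter. No other measurement bears on this result.

Since the fluorine and the carbon link leave together, unsubstituted benzyl would be needed to separate them. As far as these compounds go, whether a carboxylic acid or an amine on a longer chain at this nitrogen would move the number beyond the scatter remains open.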